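The source may report more compounds than this note shows. Statements on the series, on what has been measured and on what is new or still open speak of the compounds shown alone.

Compound 1 `C=CC1=C(C(=O)NCC(C)C)C(c2ccc(F)cc2)OC1` gives > 100000 nM in a functional assay on HeLa cells (Homo sapiens) for cytotoxicity, read by MTT assay, with a stated time of 24 h; on this read-out higher numbers stand for weaker inhibition and lower numbers for stronger inhibition; this is a limit of the assay, not a number.
Compound 2 `C=CC1=C(C(=O)NCC(C)C)C(c2ccc(Cl)c(Cl)c2)OC1` gives 60100 nM in this assay.
Compound 3 `C=CC1=C(C(=O)NC(C)(C)C)C(c2ccc(Cl)c(Cl)c2)OC1` gives > 100000 nM in this assay; this too is a limit of the assay.

All three compounds share the same core, and compound 4 `C=CC1=C(C(=O)NC(C)(C)C)C(c2ccc(F)cc2)OC1`, which is yet to be measured in this assay, belongs to the same set. Compound 1 and compound 2 differ in more than one place, and the difference between their cores is not broken down here.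

One change occurs twice among these compounds. From compound 2 to compound 3 it reads (tert-butyl in place of isobutyl on an amide-type nitrogen), and in this assay it made an at least 1.6-fold higher number from compound 2 to compound 3 (0.22 log units; that floor lies within the scatter). The same change, at the same place, takes compound 1 to compound 4: tert-butyl in place of isobutyl on an amide-type nitrogen.

Compound 1 already sits at the limit of > 100000 nM in this assay, at which 2 of the 3 values shown sit. The measured step points to a higher number, though its floor lies within the scatter, so compound 4 is expected to give a number at or beyond the limit as well. The step from compound 1 to compound 4 in this assay is estimated at a step that the limit leaves unreadable from compound 1 to compound 4. For compound 4 the expected value in this assay is 160000 nM, with a range of 80000 nM to 400000 nM, and most likely the assay will again report only a limit.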

Compound 4, half-maximal inhibitory concentration: > 100000 nM
Compound 4: a limit, no number (the forecaster's own chance of this, stated with the estimate: 85%); the middle value is on the limit's open side.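

Compound 1 and compound 4 both stop at a limit of the assay in this assay, so no step can be read between them: the limit of > 100000 nM in this assay, at which 3 of the 4 values shown sit.

The compounds shown leave open how large the change from isobutyl to tert-butyl on the amide-type nitrogen really is in this pair, and whether compound 1, compound 3 and compound 4 differ at all past that limit.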